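The compounds below may be only part of what the source reports. "The series", "measured", "known", "first", "only" and "open" are said of these compounds alone.

Three compounds built on one shared core open this account. Compound 1 `COc1ccc(-n2c(S)nnc2Sc2nnc(-c3ccccc3)n2-c2ccccc2)cc1` in a functional assay on MDA-MB-231 cells (Homo sapiens) for inhibition, read by MTT assay, with a stated time of 48 h (on this read-out higher numbers stand for weaker inhibition and lower numbers for stronger inhibition), gives "not determined" (no result reported), and compound 3 `CC(C)n1c(S)nnc1Sc1nnc(-c2ccccc2)n1-c1ccccc1` in this assay gives "not determined" (no result reported), so for each of them no result was reported. For the measured compounds named here, compound 2 `Sc1nnc(CSc2nnc(-c3ccccc3)n2-c2ccccc2)n1-c1ccccc1` is therefore the only member of the set with a number: in this assay compound 2 gives 8570 nM, and that single figure is the whole of what is known, with two further entries beside it carrying no value at all. Compound 2 thus stands alone, neither stronger nor weaker than anything else on this read-out. Nothing else was measured.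

The step of interest leads to compound 4 `Sc1nnc(CSc2nnc(-c3ccccc3)n2-c2ccccc2)n1-c1ccc(Cl)cc1`. Compared with compound 2 the difference is chloro in place of hydrogen on an aromatic carbon, sitting on an aromatic carbon of a six-membered aromatic ring of carbon only, para to a large group. Going by the values given here, no step between two measured compounds is available to calibrate how such a change behaves here. With only the value of compound 2 in this assay as an anchor, the expected shift is small, if anything a slight move toward stronger inhibition, and quite possibly none beyond the usual scatter. Compound 4 is accordingly estimated to give about 6000 nM in this assay, within a range from 2500 nM to 15000 nM, which would mean an expected step of a 1.4-fold lower number from compound 2 to compound 4 (0.15 log units; within the scatter).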

Compound 4, half-maximal inhibitory concentration: 50300 nM
Estimate against measurement, compound 4: 8.4-fold (0.92 log units) below; the whole stated range lies below it.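

For the compounds shown here, the step gives the first reading of this position: in this assay, chloro in place of hydrogen on an aromatic carbon, para to a large group, brings a 5.9-fold higher number from compound 2 to compound 4 (0.77 log units; beyond the scatter), so the change from phenyl to 4-chlorophenyl weakens inhibition. Going by these compounds alone, compound 2 alone, with its single number, could not show whether this ring position responds to substitution at all; this pair shows that, for this one added chlorine atom, it does, and by more than the usual scatter. Nothing in the data shown bears on why the number rises.

The compounds shown leave open whether this weakening is particular to chloro or would also appear with another group at the same place, such as fluoro, an amine or a carboxylic acid, since a single substituent at a single place cannot separate these cases. They also leave open whether a different group on this ring could move the number in this assay the other way, toward stronger inhibition than compound 2 gives.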